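A few compounds are considered here, and "the series" means these few. Any claim that something is new, unique, unknown or untested is made for them only; others in the source may bear on it.

Compound 2, with the structure `COc1cc(-c2nn(-c3cccc(NC(=O)Nc4ccc(Cl)c(Cl)c4)c3)cc2-c2ccncc2)ccc1Cl`, is the stronger of the two compounds measured in a functional assay on NCI-H522 cells (Homo sapiens) for inhibition, read by sulforhodamine B assay, with a stated time of 48 h (a lower number here means a stronger inhibitor of growth, a higher number a weaker inhibitor of growth), where compound 2 gives 3100 nM. Compound 1, the structure `O=C(Nc1cccc(-n2cc(-c3ccncc3)c(-c3ccc(Cl)c(O)c3)n2)c1)Nc1cccc(C(F)(F)F)c1`, gives 14500 nM in this assay, a weaker result that lies beyond the scatter of the method. Compound 1 and compound 2 differ in more than one place, so their two values alone cannot be traced to a single change.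

Compound 3, with the structure `O=C(Nc1cccc(-n2cc(-c3ccncc3)c(-c3ccc(Cl)c(O)c3)n2)c1)Nc1ccc(Cl)c(Cl)c1`, has not been measured. Relative to compound 2 the change is hydrogen in place of methyl on an oxygen on an aromatic ring. Within the data shown here, no single-point step between measured compounds is available to calibrate this change, so the expectation rests on compound 2 alone: a step from compound 2 to compound 3 of a 1.5-fold higher number from compound 2 to compound 3 (0.16 log units; within the scatter) is expected, which is a modest weakening that may not clear the scatter. Compound 3 is therefore estimated at 4500 nM, within a range from 1500 nM to 15000 nM.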

Compound 3, concentration for total growth inhibition: 10600 nM
Compound 3: middle estimate off by 2.4-fold (0.37 log units), on the low side; the range from low to high includes it.
By their numbers in this assay, from the lowest: compound 2; then compounds 3 and 1 (each within the scatter of the next).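

Swapping methoxy for hydroxy on the 4-chloro-3-methoxyphenyl group gives a 3.4-fold higher number from compound 2 to compound 3 (0.53 log units; beyond the scatter), so in this assay this position responds to this single change, with the methoxy compound giving the lower number. With the hydroxy group kept, placing 3,4-dichlorophenyl where 3-(trifluoromethyl)phenyl stood on an amide-type nitrogen gives a 1.4-fold lower number from compound 1 to compound 3 (0.14 log units; within the scatter), so compound 1 and compound 3 cannot be told apart here. Of these two single changes, only the first clears the scatter.

The compounds shown leave open whether a longer chain on that oxygen, such as ethoxy, or an amine in place of the oxygen group would give a lower or a higher number than methoxy. Nothing available explains why the methoxy and hydroxy compounds differ.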